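Notes on the step from compound 2 to compound 4

The source may hold more compounds than are shown below. What is called first, only, known or untested is meant among the compounds shown, and "the series" means these compounds.

Measured so far in a functional assay for inhibition, read by fluorescence and spectrophotometry, with a stated time of 30 h; a lower number here means a stronger inhibitor, a higher number a weaker inhibitor
compound 1 `COc1cc(-c2cc(=O)c3ccc(O)cc3o2)cc(OC)c1OC` gives 51400 nM
compound 2 `COc1ccc(-c2cc(=O)c3ccc(OCCCCN4CCC(CCO)CC4)cc3o2)cc1` gives 38400 nM
compound 3 `COc1ccc(-c2cc(=O)c3ccc(OCCCCCN4CCC(C)CC4)cc3o2)cc1` gives 55100 nM

For the measured compounds named here, compound 2 stands within the scatter of both compound 1 and compound 3, so these three numbers set no order among the compounds. Compound 4 `COc1ccc(-c2cc(=O)c3ccc(OCCCCCCCN4CCC(CCO)CC4)cc3o2)cc1` has not been measured and carries a group of 12 heavy atoms (10 carbon, 1 nitrogen, 1 oxygen; one six-membered non-aromatic ring with 1 hetero atom) in place of a group of 9 heavy atoms (7 carbon, 1 nitrogen, 1 oxygen; one six-membered non-aromatic ring with 1 hetero atom), on a saturated chain carbon, four bonds along the chain from an oxygen on an aromatic ring when set against compound 2. One measured step replaces the same 4-(2-hydroxyethyl)piperidin-1-yl group on the same saturated chain carbon, and a 1.4-fold higher number from compound 2 to compound 3 (0.16 log units; within the scatter) stays within the scatter. On that single step, in this assay no change beyond the scatter is expected for compound 4 and the support for this is thin. The estimated step is a 1.2-fold lower number from compound 2 to compound 4 (0.07 log units; within the scatter) and is expected to stay inside the scatter. For compound 4 the expected value is 33000 nM with an estimated range from 12000 nM to 70000 nM on these numbers.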

Compound 4, half-maximal inhibitory concentration: 52700 nM
Beside the measured number, compound 4's estimate is 1.6-fold (0.20 log units) below it, and the stated range covers the measured number.
By their numbers in this assay, from the lowest: compounds 2, 1, 4 and 3 (each within the scatter of the next).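

In this assay, the group of 12 heavy atoms reads no differently from the 4-(2-hydroxyethyl)piperidin-1-yl group it replaces on this saturated chain carbon (a 1.4-fold higher number from compound 2 to compound 4 (0.14 log units; within the scatter)). The comparison with the methylpiperidine compound also stays inside the scatter (a 1.0-fold lower number from compound 3 to compound 4 (0.02 log units; within the scatter)), so neither new step separates compound 4 from the compounds that it is set against. Across these steps, enlarging the group on the chain has so far produced no readable change, and the hydroxyethyl and methyl ends have not been told apart in this assay.

From the compounds shown here alone, whether a longer chain than that of compound 4, or a carboxylic acid in place of the hydroxyl of the 2-hydroxyethyl group, would move the number beyond the scatter remains open. No supporting finding is available to account for how close these numbers lie.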